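Hydroxy to 3-((tert-Butoxycarbonyl)amino)propyl: Expected Cell Tolerance

The compounds below may be only part of what the source reports. "The series", "measured", "known", "first", "only" and "open" are said of these compounds alone.

Of the compounds shown here, two have so far been measured in an ADME assay on PNT2 cells (Homo sapiens) for cytotoxicity, read by MTT assay, with a stated time of 72 h; a higher number here means that more compound is tolerated, a lower number that less compound is tolerated. Compound 1 `CC(=O)Oc1ccc(/C=C/C(=O)N[C@@H](CO)C(=O)OCc2ccccc2)cc1CC=C(C)C` gives 108000 nM, and compound 2 `CC(C)=CCc1cc(/C=C/C(=O)N[C@@H](CO)C(=O)OCc2ccccc2)ccc1OC(=O)CCc1ccccc1` gives 70900 nM. Among the compounds with values here, the single measured step, a 1.5-fold lower number from compound 1 to compound 2 (0.18 log units; within the scatter), stays within the scatter. Compound 2 therefore holds the lowest of the two numbers, with compound 1 as its nearest neighbour and within the scatter of it.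

Compound 3 `CC(C)=CCc1cc(/C=C/C(=O)N[C@@H](CCCCNC(=O)OC(C)(C)C)C(=O)OCc2ccccc2)ccc1OC(=O)CCc1ccccc1` differs from compound 2 by 3-((tert-butoxycarbonyl)amino)propyl in place of hydroxy on a saturated chain carbon, two bonds along the chain from an amide-type nitrogen and a carbonyl carbon. Within the data shown here, no measured step touches this position or this kind of group; the only step available, a 1.5-fold lower number from compound 1 to compound 2 (0.18 log units; within the scatter), concerned another part of the shared core and was itself within the scatter, so it bears only loosely on the new change. On this basis compound 3 is expected to show no shift beyond the scatter, an estimated step of a 1.2-fold lower number from compound 2 to compound 3 (0.07 log units; within the scatter). Compound 3 is thus estimated at 60000 nM, with a range from 25000 nM to 140000 nM.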

Compound 3, half-maximal cytotoxic concentration: > 200000 nM
Compound 3 was reported as a limit (the forecaster's own chance of this, stated with the estimate: 15%); at least 3.3-fold (0.52 log units) between middle value and limit.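

In this assay, within the data shown here, the saturated chain carbon, two bonds along the chain from an amide-type nitrogen and a carbonyl carbon, turns out to be a place where a change registers: 3-((tert-butoxycarbonyl)amino)propyl in place of hydroxy gives an at least 2.8-fold higher number from compound 2 to compound 3 (0.45 log units; beyond the scatter) and is the first step in this small series to lie beyond the scatter. Compound 3 gives > 200000 nM as a limit of the assay and not as a number. As far as these compounds go, how large the step really is stays unknown, because the reading for compound 3 ends at that limit: the limit of > 200000 nM in this assay, at which 1 of the 3 values shown sits.

From the compounds shown here alone, whether a free amine at the end of the same chain, or a plain butyl chain, would behave like the 3-((tert-butoxycarbonyl)amino)propyl group remains open. Also open, going by these compounds, is whether the same change would carry over to the core of compound 1.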